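This account rests on a few compounds, and the source may have more. Where it says the series, first, only, none or still open, it means among the compounds named here.

Measured compounds:
- compound 1 `CCNC(=O)c1noc(-c2cc(C(C)C)c(O)cc2O)c1-c1cc(CO)no1` gives 5 nM in a functional assay on A2780 cells (Homo sapiens) for inhibition; a lower number here means a stronger inhibitor, a higher number a weaker inhibitor
- compound 2 `CCNC(=O)c1noc(-c2cc(C(C)C)c(O)cc2O)c1-c1cc(CN)no1` is reported as "not determined" (no result reported) in this assay
- compound 3 `CCCNCc1cc(-c2c(C(=O)NCC)noc2-c2cc(C(C)C)c(O)cc2O)on1` is reported as "not determined" (no result reported) in this assay

For the measured compounds named here, compound 1 carries the only number in the set; compounds 2 and 3 were not assigned a value, so no comparison between measured compounds is available and no step within or beyond the scatter can be stated from the data themselves. Compound 4 `CCNC(=O)c1noc(-c2cc(C(C)C)c(O)cc2O)c1-c1cc(C(=O)NC)no1` is the open entry. Against compound 1 it shows (methylcarbamoyl in place of hydroxymethyl on an aromatic carbon), the core of compound 1 otherwise kept whole, with the change sitting on an aromatic carbon of a five-membered aromatic ring with 1 nitrogen and 1 oxygen. With a single measured value to lean on, the expectation in this assay is a step from compound 1 to compound 4 of about the size of the scatter, if anything a small loss rather than a gain. For compound 4 the estimated value in this assay is 8 nM, with a range from 2.5 nM to 25 nM. That estimate corresponds to an expected step of a 1.6-fold higher number from compound 1 to compound 4 (0.20 log units; within the scatter).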

Compound 4, half-maximal inhibitory concentration: 100 nM
Compound 4: middle estimate off by 13-fold (1.10 log units), on the low side, outside the stated range (above it).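

In this assay, the aromatic carbon next to the ring nitrogen proves sensitive to its substituent: methylcarbamoyl in place of hydroxymethyl gives a 20-fold higher number from compound 1 to compound 4 (1.30 log units; beyond the scatter). The two groups have the same hydrogen-bond donor and acceptor counts, so those counts alone do not track this step; the entering group differs in having more heavy atoms and a double bond outside aromatic rings. No measurement shown bears on the origin of the step.

For the compounds shown here, the steps to compounds 2 and 3 cannot be read, so compound 4 remains the only measured comparison with compound 1 at this position. A primary carboxamide or a carboxylic acid here would help show whether the rise follows the carbonyl or the added methyl on the amide nitrogen.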